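Aryl exchange at the shared core: furan-3-yl for phenyl

The compounds below may be only part of what the source reports. "The series", "measured", "known", "first", "only" and "open" are said of these compounds alone.

Among the compounds with values here, compound 2 `Nc1ncnn2c([C@@H]3O[C@H](CO)[C@@H](O)[C@H]3O)cc(-c3ccccc3)c12` carries the highest of the two numbers measured so far: in a functional assay on CAPAN-1 cells (Homo sapiens) for antiproliferative activity, with a stated time of 72 h (on this read-out higher numbers stand for weaker inhibition and lower numbers for stronger inhibition), compound 2 gives 65200 nM. Within the data shown here, compound 1 `CCCCC#Cc1cc([C@@H]2O[C@H](CO)[C@@H](O)[C@H]2O)n2ncnc(N)c12`, with hex-1-yn-1-yl in place of the phenyl, gives 1000 nM in this assay, and the step of a 65-fold higher number from compound 1 to compound 2 (1.81 log units; beyond the scatter) is the only measured step.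

Compound 3 `Nc1ncnn2c([C@@H]3O[C@H](CO)[C@@H](O)[C@H]3O)cc(-c3ccoc3)c12` differs from compound 2 in one place: furan-3-yl in place of phenyl on an aromatic carbon. Among the measured compounds shown here, no measured step exchanges one aromatic ring for another, so the step of a 65-fold higher number from compound 1 to compound 2 (1.81 log units; beyond the scatter) bears on compound 3 only indirectly, by showing that what stands at this position can move the number a great deal. For the change of phenyl to furan-3-yl a small step is expected, if anything toward a lower number, but nothing that can be anticipated beyond the scatter. Compound 3 is therefore estimated at 40000 nM in this assay, with a range from 8000 nM to 200000 nM, which means an expected step of a 1.6-fold lower number from compound 2 to compound 3 (0.21 log units; within the scatter).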

Compound 3, half-maximal inhibitory concentration: 900 nM
Compound 3: middle estimate off by 44-fold (1.65 log units), on the high side; measured number outside the range, below it.
By their numbers in this assay, from the lowest: compounds 3 and 1 (each within the scatter of the next); then compound 2.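

In this assay, the exchange gives a 72-fold lower number from compound 2 to compound 3 (1.86 log units; beyond the scatter), so at this aromatic carbon the outcome does not depend on the swap of a chain for a ring alone: one aromatic ring in place of another also produces a large step. Hex-1-yn-1-yl and furan-3-yl give numbers that cannot be told apart, with a 1.1-fold lower number from compound 1 to compound 3 (0.05 log units; within the scatter), which leaves phenyl as the only one of the three groups with a high number. Nothing available on these compounds accounts for phenyl standing apart.

Open, as far as these compounds go, is whether the high number belongs to phenyl in particular or would also appear with a pyridine or thiophene ring at this position. Also open, from the compounds shown here alone, is how a shorter alkyne chain or an aminomethyl group would compare with hex-1-yn-1-yl and furan-3-yl.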